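Acyl variation on a phenyl-pyrazoline piperidine series

The compounds below may be only part of what the source reports. "The series", "measured", "known", "first", "only" and "open" are said of these compounds alone.

Measured so far in a physicochemical assay for lipophilicity, read by HPLC, measured as chromatographic lipophilicity, at pH 7.4; on this read-out higher numbers stand for higher lipophilicity and lower numbers for lower lipophilicity:
compound 1 `O=C(c1cscn1)N1CCC(C(=O)N2N=CC[C@H]2c2ccccc2)CC1`: 3
compound 2 `O=C(C1CCCCC1)N1N=CCC1c1ccccc1`: 5.9
compound 3 `O=C(c1ccccc1)N1CCC(C(=O)N2N=CCC2c2ccccc2)CC1`: 4.4

Compound 3 stands second highest of the three numbers in this assay. Its nearest neighbour is compound 1, whose value of 3 is lower by a margin beyond the scatter; compound 2, at 5.9, lies furthest from it and higher, again beyond the scatter. Within the data shown here, none of the three differ from one another in a single place, so no measured step is available.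

Compound 4 `CC(=O)N1CCC(C(=O)N2N=CCC2c2ccccc2)CC1` is not yet measured. Against compound 3 the change is methyl in place of phenyl on a carbonyl carbon; cut one bond further out it reads benzoyl to acetyl. A step in this assay is expected to be downward and well beyond the scatter, since in compound 1 a smaller aromatic ring in the same position already gives 3 against compound 3 at 4.4. The expected step is a number 1.80 log units lower from compound 3 to compound 4 (beyond the scatter). Compound 4 is estimated at 2.6, with a range from 2 to 3.2.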

Compound 4, distribution coefficient: 2.5
Estimate against measurement, compound 4: 0.10 log units above; the range from low to high includes it.
By their numbers in this assay, from the lowest: compound 4; then compound 1; then compound 3; then compound 2.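

In this assay this position proves highly sensitive: methyl in place of phenyl on a carbonyl carbon gives a large step, a number 1.90 log units lower from compound 3 to compound 4 (beyond the scatter), with the rest of the structure unchanged. This pair gives the series its first measured single-place change, so the size of the benzoyl to acetyl change can now be read directly rather than inferred from compounds differing in several places. Nothing measured here explains the size of this step.

As far as these compounds go, one step gives only two points at this position, so it remains open where a longer chain such as butyl, or a chain ending in an amine or a carboxylic acid, would fall relative to methyl and phenyl. From the compounds shown here alone, whether the same change gives a step of similar size on another core also remains open.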